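Triazole amide series: para hydroxy in place of chloro

This account rests on a few compounds, and the source may have more. Where it says the series, first, only, none or still open, it means among the compounds named here.

Measured so far in a functional assay on HepG2 cells (Homo sapiens) for inhibition, read by MTT assay, with a stated time of 24 h; on this read-out higher numbers stand for weaker inhibition and lower numbers for stronger inhibition:
compound 1 `CC1(C)[C@H]2CC[C@]1(C)N(Cc1cn(-c3ccc(Cl)cc3)nn1)C(=O)C2`, 90 nM;
compound 2 `CC1(C)[C@H]2CC[C@]1(C)N(Cc1cn(-c3ccc(F)cc3)nn1)C(=O)C2`, 90 nM;
compound 3 `CC1(C)[C@H]2CC[C@]1(C)N(Cc1cn(-c3cccc(F)c3)nn1)C(=O)C2`, 80 nM.

Compound 1 sits level with compound 2 at the digits shown, both carrying the highest numbers of the three, with compound 3 nearest below; none of the three is separated from the others beyond the scatter (no change at the digits printed from compound 1 to compound 2 (within the scatter); a 1.1-fold lower number from compound 1 to compound 3 (0.05 log units; within the scatter); a 1.1-fold lower number from compound 2 to compound 3 (0.05 log units; within the scatter)).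

Compound 4 `CC1(C)[C@H]2CC[C@]1(C)N(Cc1cn(-c3ccc(O)cc3)nn1)C(=O)C2` is not yet measured. It differs from compound 1 as follows: hydroxy in place of chloro on an aromatic carbon.

The measured steps concern only one halogen in place of another, or a move of the halogen around the ring, and all stayed within the scatter. Among the compounds with values here, no step trades a halogen for a hydroxy group, so they bear on the new step only loosely. Within the data shown here, with no precedent for a donor at this site, a modest rise in the number is expected, a 1.8-fold higher number from compound 1 to compound 4 (0.25 log units; within the scatter), in this assay . Compound 4 is therefore estimated at 160 nM, with a range from 60 nM to 450 nM.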

Compound 4, half-maximal inhibitory concentration: 80 nM
Beside the measured number, compound 4's estimate is 2.0-fold (0.30 log units) above it; the range from low to high includes it.
By their numbers in this assay, from the lowest: compounds 3, 4, 1 and 2 (each within the scatter of the next).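

In this assay, at this site para to a large group, hydroxy in place of a halogen gives a 1.1-fold lower number from compound 1 to compound 4 (0.05 log units; within the scatter) and a 1.1-fold lower number from compound 2 to compound 4 (0.05 log units; within the scatter), while the change from 3-fluorophenyl gives no change at the digits printed from compound 3 to compound 4 (within the scatter). The site therefore accepts a hydrogen-bond donor as well as a halogen without a step beyond the scatter, which the halogen-only compounds could not show. No supporting measurement accounts for this flat read-out.

Open, from the compounds shown here alone, is whether a methoxy group, an amine or a carboxylic acid at the same site would also stay within the scatter. Going by these compounds, a longer chain there remains equally open.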